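A few compounds are considered here, and "the series" means these few. Any claim that something is new, unique, unknown or untested is made for them only; others in the source may bear on it.

Working notes on the series. Two members of the shared core have been measured in a functional assay on MCF7 cells (Homo sapiens) for cytotoxicity, read by sulforhodamine B assay, with a stated time of 48 h; a higher number here means a weaker inhibitor, a lower number a stronger inhibitor. Compound 1 `Clc1ccc(-c2csc3ncnc(N4CCN(c5ccccc5)CC4)c23)cc1` gives 34.2 nM. Compound 2 `O=[N+]([O-])c1ccc(-c2csc3ncnc(N4CCN(c5ccccc5)CC4)c23)cc1` carries a nitro group where compound 1 carries a chloro, and in this assay compound 2 gives 28.7 nM. The step of a 1.2-fold lower number from compound 1 to compound 2 (0.08 log units; within the scatter) is within the scatter, so compound 2 stands together with compound 1 rather than apart from it; no separation between the two has been shown.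

Compound 3 `O=[N+]([O-])c1ccc(-c2csc3ncnc(N4CCN(c5ccc(Cl)cc5)CC4)c23)cc1` is the next member. Relative to compound 2 the change is chloro in place of hydrogen on an aromatic carbon. Within the data shown here, the one measured step, that from compound 1 to compound 2, concerns a different aromatic ring and a different exchange, so it bears only loosely on this change; what it shows is that an exchange on an aromatic carbon of the outer rings left the number within the scatter. On that basis the expected step of a 1.0-fold lower number from compound 2 to compound 3 (0.01 log units; within the scatter) is none beyond the scatter. For compound 3 the estimate in this assay is 28 nM, with a range from 12 nM to 70 nM.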

Compound 3, half-maximal inhibitory concentration: 54.4 nM
The estimate for compound 3 lay 1.9-fold (0.29 log units) below the measured number; the measured number falls inside the stated range.
By their numbers in this assay, from the lowest: compounds 2, 1 and 3 (each within the scatter of the next).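

In this assay, the change from phenyl to 4-chlorophenyl is the first exchange shown on this six-membered aromatic ring of carbon only, and it gives a 1.9-fold higher number from compound 2 to compound 3 (0.28 log units; within the scatter), so chloro in place of hydrogen, para to a large group, does not separate compound 3 from compound 2. Read with a 1.2-fold lower number from compound 1 to compound 2 (0.08 log units; within the scatter), which concerns the other outer aromatic ring, this means that both exchanges shown on aromatic carbons of the outer rings stay within the scatter, and the series so far holds no compound that stands apart from its neighbour in a single step. Nothing available bears on the reason for the number of compound 3, and with a step of this size there is no effect of the chloro to explain.

On these data alone, whether an amine, a carboxylic acid or a longer chain such as butyl at this same place on the ring would give a step beyond the scatter remains open. Also open, as far as these compounds go, is whether chloro at this place gives a similar step when the other outer aromatic ring carries chloro rather than nitro.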